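The source may hold more compounds than are shown below. What is called first, only, known or untested is meant among the compounds shown, and "the series" means these compounds.

Measured compounds in an ADME assay on RAW264.7 cells (Mus musculus) for cytotoxicity, read by WST assay; on this read-out lower numbers stand for higher toxicity in this test and higher numbers for lower toxicity in this test:

- Compound 1 `O=C(NCc1ccco1)c1ccc(CN2C(=O)c3ccccc3S2(=O)=O)cc1`: in this assay compound 1 gives > 100000 nM, which is a limit of the assay and not a number.
- Compound 2 `O=C(c1ccc(Cn2sc3ccccc3c2=O)cc1)N1CCCCC1`: in this assay compound 2 gives > 100000 nM, again a limit of the assay.
- Compound 3 `CNC(=O)c1ccc(CN2C(=O)c3ccccc3S2(=O)=O)cc1`: in this assay compound 3 gives > 100000 nM, also a limit of the assay.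

Compound 3 therefore stands only at a limit in this assay, and every value shown for the series sits at that same limit (the limit of > 100000 nM in this assay, at which 3 of the 3 values shown sit). Going by the values given here, the one measured step, a step that the two limits leave unreadable from compound 1 to compound 3, cannot be sized from the two limits. Compound 4 `CC(=O)N(Cc1ccco1)C(=O)c1ccc(CN2C(=O)c3ccccc3S2(=O)=O)cc1` differs from compound 3 by acetyl((furan-2-yl)methyl)amino in place of methylamino on a carbonyl carbon. Among the compounds with values here, the only measured step that touches the same amide position is a step that the two limits leave unreadable from compound 1 to compound 3, which is unreadable, so no direction and no size of change beyond the scatter can be derived for this assay; the expectation for the step from compound 3 to compound 4 is simply a number no higher from compound 3 to compound 4 (the limit leaves the size open), with compound 4 expected to remain at the limit. On this basis compound 4 is estimated at 100000 nM in this assay, with a range from 50000 nM to 300000 nM.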

Compound 4, concentration lethal to 50% of the cells: > 100000 nM
Compound 4 ended at the assay's limit; the forecaster's own chance of this, stated with the estimate: 80%; the middle value lies on the limit itself.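

Compound 4 stays at the assay limit, so neither the step from compound 3 to compound 4 nor that from compound 1 to compound 4 can be read in this assay: the limit of > 100000 nM in this assay, at which 4 of the 4 values shown sit.

The compounds shown leave open how far each lies past that limit, and whether any amide substituent gives a measurable value in this assay.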